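Ethoxy for Ethyl: Expecting the Next Reading

The source may hold more compounds than are shown below. What is called first, only, known or untested is meant among the compounds shown, and "the series" means these compounds.

Compound 2 `CCc1ccc(NCN2C(=O)c3ccccc3C2=O)cc1` stands highest of the two compounds measured in an assay on isolated protein for inhibition of ribosomal protein S6 kinase alpha-2 (Homo sapiens), read by fluorescence, with a stated time of 20 min, tested at 10 uM; on this read-out lower numbers stand for less inhibition and higher numbers for more inhibition at the one concentration tested (going by the name of the read-out): compound 2 gives 63%, while compound 1 `O=C1c2ccccc2C(=O)N1CNc1ccc(Cl)cc1` gives 8.52%. For the measured compounds named here, the only measured step is a number 54.5 percentage points higher from compound 1 to compound 2 (beyond the scatter), and it concerns the same aromatic carbon that changes here. Compound 3 `CCOc1ccc(NCN2C(=O)c3ccccc3C2=O)cc1` has not yet been measured; it differs from compound 2 in one place: ethoxy in place of ethyl on an aromatic carbon. Going by the values given here, the known step shows that this position can move the read-out by a large amount, but no measured pair shows what an ethoxy does in place of an ethyl there. The expectation for compound 3 therefore rests on compound 2 alone, with a wide range. The step expected from compound 2 to compound 3 is a number 8 percentage points lower from compound 2 to compound 3 (within the scatter), which is estimated to stay within the scatter. Compound 3 is thus estimated at 55%, within a range of 25% to 80%.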

Compound 3, a percentage reported as inhibition, at one concentration (the size of the read-out at that concentration, not a potency): 100%
Compound 3: middle estimate off by 45 percentage points, on the low side, and the stated range ends below it.
By their numbers in this assay, from the lowest: compound 1; then compound 2; then compound 3.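

Putting ethoxy in place of ethyl on this aromatic carbon, para to a large group, gives a number 37 percentage points higher from compound 2 to compound 3 (beyond the scatter) in this assay, so the reading at this position can climb well past the level that ethyl reached. The earlier pair showed only that ethyl stands above chloro here; ethoxy in place of chloro now gives a number 91.5 percentage points higher from compound 1 to compound 3 (beyond the scatter), and compound 3 stands highest of the three, with both of its steps beyond the scatter. The ethyl-to-ethoxy change adds an oxygen to the chain, and on the shared core that single change is enough for a large step.

From the compounds shown here alone, what a methoxy, a propyl chain or an amine would do on this carbon stays open, as does how compound 3 ranks at any other concentration. Nothing at hand gives a reason for these rises.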